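This account rests on a few compounds, and the source may have more. Where it says the series, first, only, none or still open, it means among the compounds named here.

Measured so far in an ADME assay on HepG2 cells (Homo sapiens) for inhibition, with a stated time of 72 h; on this read-out higher numbers stand for an effect only at larger amounts of compound and lower numbers for an effect already at smaller amounts:

Compound 1 `C/C=C/C(=O)Nc1cccc(-c2nc3ccccc3s2)c1` gives > 25000 nM, a limit of the assay rather than a number.
Compound 2 `O=C(O)/C=C/C(=O)Nc1cccc(-c2nc3ccccc3s2)c1` gives > 25000 nM, likewise a limit of the assay.
Compound 3 `O=C(CCl)Nc1cccc(-c2nc3ccccc3s2)c1` gives 16000 nM.

Going by the values given here, compound 3 thus holds the only number among the three; the other two sit at the limit of > 25000 nM in this assay, at which 2 of the 3 values shown sit. The steps that reach compound 3 both exchange the group on the carbonyl carbon: an at least 1.5-fold lower number from compound 1 to compound 3 (0.19 log units; that floor lies within the scatter) and an at least 1.5-fold lower number from compound 2 to compound 3 (0.19 log units; that floor lies within the scatter). Each is only a floor, and that floor lies within the scatter, so they give a direction at most faintly.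

Compound 4 `O=C(Nc1cccc(-c2nc3ccccc3s2)c1)c1cnccc1Cl` differs from compound 3 in the same place: 4-chloropyridin-3-yl in place of chloromethyl on a carbonyl carbon. Among the compounds with values here, no measured step swaps a chloromethyl for an aromatic group on this carbonyl carbon, so the two floors above are all there is to lean on, and they point to no clear change. The step from compound 3 to compound 4 is therefore expected to be a 1.3-fold higher number from compound 3 to compound 4 (0.10 log units; within the scatter), roughly level with the scatter. Compound 4 is accordingly estimated at 20000 nM, with a range from 5000 nM to 80000 nM, and a real chance that only a limit is reported.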

Compound 4, half-maximal effective concentration: > 25000 nM
Compound 4: no number, only a limit; the forecaster's own chance of this, stated with the estimate: 40%; middle value at least 1.2-fold (0.09 log units) away from the limit.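

In this assay, putting 4-chloropyridin-3-yl in place of chloromethyl on the carbonyl carbon gives an at least 1.5-fold higher number from compound 3 to compound 4 (0.19 log units; that floor lies within the scatter) and so shows that this aromatic group, like the two open chains before it, yields no readable number here. The steps from compound 1 and from compound 2 to compound 4 cannot be read, as both ends of each are limits. Compound 3 therefore remains alone with a number, while the other compounds share one limit: the limit of > 25000 nM in this assay, at which 3 of the 4 values shown sit.

Going by these compounds alone, it remains open whether a plain methyl or a bromomethyl on this carbonyl carbon would give a number, and how that number would compare with the one for compound 3. On these data alone, the real size of the change to compound 4 also stays unknown, since only a floor can be read.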